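From a Selenium Aryl Group to a Hydroxybutynyl Chain

This account rests on a few compounds, and the source may have more. Where it says the series, first, only, none or still open, it means among the compounds named here.

Compound 1 `CCOC(=O)c1cc([Se]c2ccccc2C)c2cc(OC)ccc2n1`, compound 2 `CCOC(=O)c1cc(C#Cc2ccc(N)cc2)c2cc(OC)ccc2n1` and compound 3 `CCOC(=O)c1cc([Se]c2ccc(F)cc2)c2cc(OC)ccc2n1` share one core and differ only in the group attached to it. In a functional assay on SK-MEL-147 cells (Homo sapiens) for cytotoxicity, read by MTT assay, with a stated time of 24 h (a lower number here means that less compound is needed, a higher number that more compound is needed for the effect), compound 1 gives 38900 nM. Compound 2 gives 8800 nM. Compound 3 reaches only a limit of the assay, > 150000 nM. Compound 3 thus sits at the limit of > 150000 nM in this assay, at which 1 of the 3 values shown sits. Among the compounds with values here, the only measured step, an at least 3.8-fold higher number from compound 1 to compound 3 (0.58 log units; beyond the scatter), runs toward that limit. Compound 4 `CCOC(=O)c1cc(C#CCCO)c2cc(OC)ccc2n1` alters compound 3 by a group of 5 heavy atoms (4 carbon, 1 oxygen; no ring) in place of a group of 8 heavy atoms (6 carbon, 1 fluorine, 1 selenium; one six-membered aromatic ring of carbon only), on an aromatic carbon. Within the data shown here, no measured pair matches this swap; compound 2 shows, however, that a triple-bonded group on this carbon can go with a lower number. Compound 4 is therefore expected to leave the limit behind, an at least 4.2-fold lower number from compound 3 to compound 4 (0.63 log units; beyond the scatter). Compound 4 is estimated at 35000 nM, somewhere from 9000 nM to 150000 nM.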

Compound 4, half-maximal effective concentration: > 150000 nM
Compound 4 gave a limit, no number; the forecaster's own chance of this, stated with the estimate: 30%; middle value at least 4.2-fold (0.63 log units) away from the limit.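

In this assay, a triple-bonded group on this carbon is not enough on its own to give a low number: 2-hydroxyethyl in place of 4-aminophenyl on the triple-bonded carbon gives an at least 17-fold higher number from compound 2 to compound 4 (1.23 log units; beyond the scatter). The change away from the selenium group of compound 1 also goes upward, with an at least 3.8-fold higher number from compound 1 to compound 4 (0.58 log units; beyond the scatter). The step from compound 3 to compound 4 cannot be read, as both values are limits of the assay: the limit of > 150000 nM in this assay, at which 2 of the 4 values shown sit.

Still open, going by these compounds, is whether compound 2 owes its lower number to the aromatic ring or to its amine. A plain phenyl or an aminoethyl group on the triple-bonded carbon would separate the two.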